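Removing a chloro group from a thiazole-linked phenol

The source may hold more compounds than are shown below. What is called first, only, known or untested is meant among the compounds shown, and "the series" means these compounds.

Compound 1 `Oc1cccc(Nc2nc(-c3ccc(Cl)cc3)cs2)c1` was tested in an assay on isolated protein for inhibition of Polyunsaturated fatty acid 5-lipoxygenase (Homo sapiens), read by HPLC, with stated times of 15 min and 10 min (a higher number here means a weaker inhibitor, a lower number a stronger inhibitor), where compound 1 gives 1200 nM, the highest of the three numbers seen. Compound 2 `Oc1ccc(Nc2nc(-c3ccc(Cl)c(Cl)c3)cs2)cc1` gives 30 nM and compound 3 `CCOc1ccc(-c2csc(Nc3ccc(O)cc3)n2)cc1` gives 30 nM, both far lower than compound 1. Compound 4 `Oc1cccc(Nc2nc(-c3ccccc3)cs2)c1` has not yet been measured. It differs from compound 1 by a single change: hydrogen in place of chloro on an aromatic carbon, para to a large group. Going by the values given here, no measured pair shows this exact change, so the expectation rests only on the general picture. A small step toward a weaker inhibitor, roughly within the scatter, is expected, a 1.7-fold higher number from compound 1 to compound 4 (0.22 log units; within the scatter). Compound 4 is therefore estimated at 2000 nM, with a likely range from 700 nM to 6000 nM.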

Compound 4, half-maximal inhibitory concentration: 3700 nM
Estimate against measurement, compound 4: 1.9-fold (0.27 log units) below; the range from low to high includes it.
By their numbers in this assay, from the lowest: compounds 2 and 3 (each within the scatter of the next); then compound 1; then compound 4.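

Putting hydrogen in place of chloro on this aromatic carbon, para to a large group, gives a 3.1-fold higher number from compound 1 to compound 4 (0.49 log units; beyond the scatter) and so a modest move toward a weaker inhibitor. Going by these compounds alone, this is the first direct reading of this position, as the earlier compounds differed from one another in more than one place. No available evidence explains the rise.

From the compounds shown here alone, whether a fluoro group, a methyl group or an amine at this position would match chloro stays open. So does whether the same change would have a similar effect in compound 3.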